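The compounds below may be only part of what the source reports. "The series", "measured", "known", "first", "only" and "open" are said of these compounds alone.

Measured compounds: compound 1 `O=C(CCCCCCCn1cc(Nc2ncc(Cl)c(Nc3ccc(F)cc3)n2)cn1)NO`, 1700 nM; compound 2 `CNc1nc(Nc2cnn(CCCCCCC(=O)NO)c2)ncc1Cl`, 4070 nM; compound 3 `O=C(CCCCCCn1cc(Nc2ncc(Cl)c(Nc3cccc(Cl)c3)n2)cn1)NO`, 840 nM, all in an assay on isolated protein for inhibition of histone deacetylase 8 (Homo sapiens), read by fluorescence, with stated times of 5 min and 30 min; on this read-out higher numbers stand for weaker inhibition and lower numbers for stronger inhibition.

Among these three numbers compound 1 stands second highest: compound 3 sits a 4.8-fold lower number from compound 2 to compound 3 (0.69 log units; beyond the scatter) away from compound 2, and compound 1 lies between them. Compound 4 `O=C(CCCCn1cc(Nc2ncc(Cl)c(Nc3ccc(F)cc3)n2)cn1)NO` differs from compound 1 by hydroxycarbamoyl in place of 3-(hydroxycarbamoyl)propyl on a saturated chain carbon, four bonds along the chain from an aromatic nitrogen. Going by the values given here, the only measured step, a 4.8-fold lower number from compound 2 to compound 3 (0.69 log units; beyond the scatter), concerns the aromatic substituent and not the chain, so no measured step bears on this change; compounds 1 and 3 differ in both chain and aryl group, and their values alone cannot separate the two. Compound 4 is therefore expected to give 4000 nM, within 1000 nM to 16000 nM, an estimated 2.4-fold higher number from compound 1 to compound 4 (0.37 log units; beyond the scatter).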

Compound 4, half-maximal inhibitory concentration: 5100 nM
The estimate for compound 4 lay 1.3-fold (0.11 log units) below the measured number, and the stated range covers the measured number.
By their numbers in this assay, from the lowest: compound 3; then compound 1; then compounds 2 and 4 (each within the scatter of the next).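

In this assay, replacing 3-(hydroxycarbamoyl)propyl with hydroxycarbamoyl on this saturated chain carbon gives a 3.0-fold higher number from compound 1 to compound 4 (0.48 log units; beyond the scatter), beyond the scatter, with the rest of the structure unchanged. Going by these compounds alone, this is the first measured step on the chain rather than the aromatic substituent, and it shows that inhibition responds to shortening at this position. No measurement on hand accounts for this change. From the compounds shown here alone, whether a longer chain than in compound 1 would lower the number remains open, as does the outcome of placing a carboxylic acid or an amine where hydroxycarbamoyl stands.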